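A few compounds are considered here, and "the series" means these few. Any claim that something is new, unique, unknown or untested is made for them only; others in the source may bear on it.

Among the compounds with values here, compound 2, with structure `CCOCC(COCC)Nc1nc(C)nc2c(-c3ccc(Cl)cc3Cl)c(C)nn12`, is one of two compounds measured in an assay on isolated protein for displacement of a labelled ligand from corticotropin-releasing factor receptor 1 (Homo sapiens); a lower number here means a stronger inhibitor, a higher number a weaker inhibitor. In this assay compound 2 gives 6.2 nM, the higher of the two numbers. The other measured compound, compound 1, has structure `CCCN(CC1CC1)c1nc(C)nc2c(-c3ccc(Cl)cc3Cl)c(C)nn12`, and in this assay compound 1 gives 0.7 nM. Compound 1 and compound 2 differ in more than one place, so these two values are shown side by side without a single structural step to connect them; they simply show that compound 2 is the weaker binder of the pair by a margin beyond the usual scatter.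

Compound 3, with structure `CCCC(CCC)Nc1nc(C)nc2c(-c3ccc(Cl)cc3Cl)c(C)nn12`, has not yet been measured. The change from compound 2 to compound 3 is 1-propylbutyl in place of 2-ethoxy-1-(ethoxymethyl)ethyl on a nitrogen on an aromatic ring. Both groups are branched chains on the same ring nitrogen, and the group that enters has no oxygen at all.

Within the data shown here, no measured step of this kind is available here. The step from compound 2 to compound 3 is expected to be modest and toward a lower number, a 2.1-fold lower number from compound 2 to compound 3 (0.32 log units; beyond the scatter), since the two measured compounds sit within a narrow range already. Compound 3 is estimated to give 3 nM in this assay, with a range from 0.8 nM to 12 nM.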

Compound 3, inhibition constant: 1.6 nM
Compound 3: the middle estimate sits 1.9-fold (0.27 log units) above what was measured; the range from low to high includes it.
By their numbers in this assay, from the lowest: compound 1; then compound 3; then compound 2.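

In this assay, the step from the 2-ethoxy-1-(ethoxymethyl)ethyl group to 1-propylbutyl is a 3.9-fold lower number from compound 2 to compound 3 (0.59 log units; beyond the scatter) and shows that, in this pair, a branched chain on this nitrogen needs no oxygen for strong binding; the group without oxygen gives the lower number. The second step, a 2.3-fold higher number from compound 1 to compound 3 (0.36 log units; beyond the scatter), shows that even this better of the two branched groups does not match the (cyclopropylmethyl)(propyl)amino group of compound 1 on the same aromatic carbon. Nothing available here explains why either step goes the way it does.

The compounds shown leave open whether a chain keeping just one ether oxygen, such as a 1-(methoxymethyl)butyl group, would fall between compound 2 and compound 3, which would show if the oxygen count tracks the binding number. They also leave open how far the branched chain can change, for example a shorter 1-ethylpropyl group, a longer 1-butylpentyl group, or a chain ending in a carboxylic acid on the same nitrogen.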